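Chloro in Place of Methyl: Estimating Compound 4

The compounds below may be only part of what the source reports. "The series", "measured", "known", "first", "only" and "open" are said of these compounds alone.

Compound 1, `Nc1ccccc1NC(=O)c1ccc(NCC(=O)Nc2ccc([N+](=O)[O-])cc2)cc1`: 77.5%
Compound 2, `Nc1ccccc1NC(=O)CCCNCC(=O)Nc1ccccc1Cl`: 12.7%
Compound 3, `Cc1ccc(NC(=O)CNc2ccc(C(=O)Nc3ccccc3N)cc2)cc1`: 25.2%

These three compounds have been tested in a functional assay on the whole organism (Ehrlich cells, Mus musculus) for antiproliferative activity, with a stated time of 24 h, at a dose of 0.2 mmol/kg by the intraperitoneal route; on this read-out higher numbers stand for more inhibition at the one dose given (going by the name of the read-out) and lower numbers for less inhibition. Among the three, compound 3 stands second; compound 2 lies below it by a gap beyond the scatter, and compound 1 lies far above it. The one step that links two of these compounds by a single change is a number 52.3 percentage points lower from compound 1 to compound 3 (beyond the scatter), a large drop when methyl replaces nitro on an aromatic carbon.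

Compound 4, `Nc1ccccc1NC(=O)c1ccc(NCC(=O)Nc2ccc(Cl)cc2)cc1`, has not yet been measured in this assay. It differs from compound 3 in one place: chloro in place of methyl on an aromatic carbon. For the measured compounds named here, no measured pair shows chloro against methyl directly, so the only guidance is that swapping the group on this aromatic carbon has moved the number a great deal in the one case seen. Chloro is a different group from both nitro and methyl, so its effect cannot be read straight from that step; a move upward from compound 3 toward compound 1 seems plausible, but with wide uncertainty.

Compound 4 is therefore expected to give about 45% in this assay, within a range from 22% to 70%, which means an estimated step of a number 19.8 percentage points higher from compound 3 to compound 4 (beyond the scatter).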

Compound 4, a percentage reported as inhibition, in the whole organism at one dose (the size of the read-out at that dose, not a potency): 73.3%
Beside the measured number, compound 4's estimate is 28.3 percentage points below it; measured number outside the range, above it.
By their numbers in this assay, from the lowest: compound 2; then compound 3; then compounds 4 and 1 (each within the scatter of the next).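

Until now only the drop from nitro to methyl was on show, and that single step could not tell whether nitro was unusually good or methyl unusually poor at this position. In this assay the change from methyl to chloro is a number 48.1 percentage points higher from compound 3 to compound 4 (beyond the scatter) and the change from nitro to chloro is a number 4.2 percentage points lower from compound 1 to compound 4 (within the scatter) on the same aromatic carbon. Strong inhibition at this one dose therefore does not depend on nitro alone: among these three compounds, which differ only in this one group, chloro and nitro give values within the scatter of each other, and methyl is the one that stands apart.

From the compounds shown here alone, whether an amine, a methoxy group or a fluoro on this carbon would fall with chloro and nitro or with methyl remains open, and so does whether a longer chain there would keep the inhibition. Nothing available here speaks to what sets methyl apart from chloro and nitro.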